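Nitro for trifluoromethyl in a thiourea pair

The compounds below may be only part of what the source reports. "The series", "measured", "known", "first", "only" and "open" are said of these compounds alone.

A small set of thioureas was tested in a functional assay on A2780 cells (Homo sapiens) for inhibition, with a stated time of 72 h, tested at 10 uM; on this read-out higher numbers stand for more inhibition of growth at the one concentration tested and lower numbers for less inhibition of growth. Compound 1, with the structure `CCC1(CC)CC(C)(C)Oc2ccc(NC(=S)Nc3ccc(C(F)(F)F)cc3)cc21`, gives 11.8% in this assay, the highest of the two numbers recorded. Compound 2, with the structure `CC1(C)CC(C)(C)c2cc(NC(=S)Nc3ccc(C(F)(F)F)cc3)ccc2O1`, gives 2% in this assay. Among the measured compounds shown here, no step between these two compounds is recorded; what the two values show is that they lie within the scatter of each other, so no order between them can be read from them.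

The next compound follows from compound 1 by a single change. Compound 3 has the structure `CCC1(CC)CC(C)(C)Oc2ccc(NC(=S)Nc3ccc([N+](=O)[O-])cc3)cc21`; the difference from compound 1 is nitro in place of trifluoromethyl on an aromatic carbon. For the measured compounds named here, no measured step of this kind is at hand, so the effect of the change must be estimated from the two values alone. Going by the values given here, both compounds measured so far lie in a low band. The step from compound 1 to compound 3 is expected to be a number 0.2 percentage points higher from compound 1 to compound 3 (within the scatter), that is no movement beyond the scatter in either direction. Compound 3 is therefore expected to give about 12% in this assay, in a range from -4% to 30%.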

Compound 3, percent growth inhibition at one concentration: 95.7%
Compound 3: the middle estimate sits 83.7 percentage points below what was measured, outside the stated range (above it).
By their numbers in this assay, from the lowest: compounds 2 and 1 (each within the scatter of the next); then compound 3.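

In this assay, the change from 4-(trifluoromethyl)phenyl to 4-nitrophenyl gives a number 83.9 percentage points higher from compound 1 to compound 3 (beyond the scatter), with the core of compound 1 untouched. Both earlier compounds carry trifluoromethyl at this place, so they could not show that the group on this aromatic carbon matters at all; this single exchange shows that it can decide whether the compound sits in the low band or far above it. No measurement at hand accounts for the size of this step, so it stands as an observation without an explanation.

The step rests on one pair, so the compounds shown leave open whether nitro is unusual at this place or whether other groups, such as a nitrile, an amine or a carboxylic acid, would also lift the read-out. They also leave open whether nitro in place of trifluoromethyl has a comparable effect on the core of compound 2, and how the inhibition of compound 3 would change at concentrations other than the single one tested.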